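This account rests on a few compounds, and the source may have more. Where it says the series, first, only, none or still open, it means among the compounds named here.

Compound 1 `CNC(=O)c1cccc(NC(=O)N2CCC(Oc3ccccc3)CC2)c1` is the reference point of this comparison. In an assay on isolated protein for inhibition of acyl-CoA desaturase 1 (Mus musculus) (on this read-out higher numbers stand for weaker inhibition and lower numbers for stronger inhibition), compound 1 gives 370 nM, which is the highest of the two numbers recorded so far. Among the measured compounds shown here, the only other measured compound, compound 2 `CNC(=O)c1cccc(NC(=O)N2CCC(Oc3ccccc3C)CC2)c1`, differs from it by a single methyl in place of hydrogen on an aromatic carbon; in this assay compound 2 gives 17 nM. For the measured compounds named here, the step is a 22-fold lower number from compound 1 to compound 2 (1.34 log units; beyond the scatter), so the one recorded change at the phenoxy ring moved the number far beyond the scatter, towards stronger inhibition.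

Compound 3 `CNC(=O)c1cccc(NC(=O)N2CCC(Oc3ccc(F)cc3Cl)CC2)c1` has not yet been measured. It differs from compound 1 as follows: 2-chloro-4-fluorophenyl in place of phenyl on an oxygen on a saturated carbon. Cut one bond further out, the change reads phenoxy to 2-chloro-4-fluorophenoxy. The step from compound 1 to compound 2 is the only one that bears on it, since it too alters the phenoxy ring; its size suggests a large step in the same direction, though a chloro and a fluoro substituent need not act as a methyl did. Compound 3 is therefore expected to give about 35 nM, between 8 nM and 150 nM. That would be an expected step of an 11-fold lower number from compound 1 to compound 3 (1.02 log units; beyond the scatter).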

Compound 3, half-maximal inhibitory concentration: 6 nM
Beside the measured number, compound 3's estimate is 5.8-fold (0.77 log units) above it, and the stated range ends above it.
By their numbers in this assay, from the lowest: compound 3; then compound 2; then compound 1.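

The phenoxy ring at this position turns out not to depend on a methyl for its gain in this assay: replacing phenyl with 2-chloro-4-fluorophenyl on the same oxygen gives a 62-fold lower number from compound 1 to compound 3 (1.79 log units; beyond the scatter), a large move towards stronger inhibition and larger than the step seen with the methyl. Halogen substitution of this ring therefore goes with a lower number as well, and the ring is shown to accept more than one kind of change. The comparison of the two substituted rings gives a 2.8-fold lower number from compound 2 to compound 3 (0.45 log units; beyond the scatter), a modest step but one that separates them, placing 2-chloro-4-fluorophenyl ahead of 2-methylphenyl, although nothing available explains why the numbers fall in this way.

The compounds shown leave open how the step divides between the chloro and the fluoro, since both enter together and neither is seen alone on the ring. They also leave open how this assay would respond to a ring carrying a methoxy, a nitrile, an amine or a carboxylic acid, and whether the gain from these rings holds if the rest of the core changes.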